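This account rests on a few compounds, and the source may have more. Where it says the series, first, only, none or still open, it means among the compounds named here.

Measured so far:
compound 1, `CNC(=O)CCCCCCCn1nc(-c2ccc3oc(N)nc3c2)c2c(N)ncnc21`: 2900 nM
compound 2, `Nc1nc2cc(-c3nn(CCCCCCCCCC(=O)NO)c4ncnc(N)c34)ccc2o1`: > 50000 nM

Both compounds were tested in a functional assay on MDA-MB-231 cells (Homo sapiens) for inhibition, read by MTT assay, with a stated time of 72 h; on this read-out lower numbers stand for stronger inhibition and higher numbers for weaker inhibition. Going by the values given here, compound 1 stands as the only compound with a definite number in this assay. Compound 2 gives only a limit of the assay, not a number, sitting at the limit of > 50000 nM in this assay, at which 1 of the 2 values shown sits.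

The unmeasured compound 3 is `Nc1nc2cc(-c3nn(CC(=O)NO)c4ncnc(N)c34)ccc2o1`. It differs from compound 1 in one place: hydroxycarbamoyl in place of 6-(methylcarbamoyl)hexyl on a saturated chain carbon bound to an aromatic nitrogen. Among the compounds with values here, the single measured step that bears on this change is an at least 17-fold higher number from compound 1 to compound 2 (1.23 log units; beyond the scatter), a large move toward weaker inhibition when a hydroxycarbamoyl-bearing group entered at the end of the chain. Within the data shown here, compound 3 carries the same hydroxycarbamoyl group, but directly on the saturated chain carbon bound to the aromatic nitrogen, with the long chain gone; no measured step tests such a shortening on its own. Compound 3 is therefore expected to show a large step toward a higher number, a 6.9-fold higher number from compound 1 to compound 3 (0.84 log units; beyond the scatter), and may itself reach the limit of this assay. The estimate for compound 3 is 20000 nM, within a range from 5000 nM to 50000 nM.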

Compound 3, half-maximal inhibitory concentration: 6310 nM
The estimate for compound 3 lay 3.2-fold (0.50 log units) above the measured number, within the range that was stated.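

In this assay, swapping 6-(methylcarbamoyl)hexyl for hydroxycarbamoyl on the saturated chain carbon bound to an aromatic nitrogen costs only a modest amount, a 2.2-fold higher number from compound 1 to compound 3 (0.34 log units; beyond the scatter), so this position tolerates losing the long chain and its methyl amide end. This move is much smaller than the earlier one, an at least 17-fold higher number from compound 1 to compound 2 (1.23 log units; beyond the scatter), which shows that the hydroxycarbamoyl group does not by itself bring the large loss; what matters is also how it is attached to the shared core. Compound 2, which carries this group at the end of a long chain, gives only a limit and not a number: the limit of > 50000 nM in this assay, at which 1 of the 3 values shown sits.

From the compounds shown here alone, the step to compound 3 changes the chain length and the end group together, so the share of each in the change remains unknown. Going by these compounds, it also remains open how a hydroxycarbamoyl group would behave on a chain of intermediate length, and whether a carboxylic acid or a primary amide in its place would give a number closer to that of compound 1.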